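From ethyl to thiophen-2-yl on the oxygen

The source may hold more compounds than are shown below. What is called first, only, known or untested is meant among the compounds shown, and "the series" means these compounds.

Going by the values given here, in a functional assay on HeLa cells (Homo sapiens) for cytotoxicity (a higher number here means a weaker inhibitor, a lower number a stronger inhibitor), compound 1 `CCCCOC1=CC(=O)c2ccccc2C1=O` gives 35300 nM and compound 2 `CCOC1=CC(=O)c2ccccc2C1=O` gives 23800 nM, so compound 2 stands level with its only neighbour: a 1.5-fold lower number from compound 1 to compound 2 (0.17 log units; within the scatter). Compound 3 `O=C1C=C(Oc2cccs2)C(=O)c2ccccc21` carries thiophen-2-yl in place of ethyl on an oxygen on an unsaturated carbon. That single measured step bears on this change only loosely, since it trims a saturated chain and tests no ring. The step expected is therefore a 1.5-fold lower number from compound 2 to compound 3 (0.17 log units; within the scatter), with nothing clearly beyond the scatter foreseen. For compound 3 the estimate is 16000 nM, with an expected range from 4000 nM to 50000 nM.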

Compound 3, half-maximal inhibitory concentration: 35300 nM
The estimate for compound 3 lay 2.2-fold (0.34 log units) below the measured number; low and high end bracket the measured number.
By their numbers in this assay, from the lowest: compounds 2, 1 and 3 (each within the scatter of the next).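

In this assay the swap to a ring on this oxygen leaves the read-out within the scatter (a 1.5-fold higher number from compound 2 to compound 3 (0.17 log units; within the scatter)) and the same holds against the butyl compound (no change at the digits printed from compound 1 to compound 3 (within the scatter)). At this position, on an oxygen on an unsaturated carbon, thiophen-2-yl therefore cannot be told apart from ethyl or butyl, so a five-membered aromatic ring does no differently here than a saturated chain. Nothing at hand explains this level result. On these data alone, whether an amine or a carboxylic acid on the oxygen substituent, or a phenyl ring in place of thiophen-2-yl, would move the number stays open.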